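Phenyl in Place of Cyclohexyl: an Expected Shift

This account rests on a few compounds, and the source may have more. Where it says the series, first, only, none or still open, it means among the compounds named here.

Measured compounds in a functional assay on WiDr cells (Homo sapiens) for antiproliferative activity, read by sulforhodamine B assay, with a stated time of 48 h; a higher number here means a weaker inhibitor of growth, a lower number a stronger inhibitor of growth:
compound 1, `Cc1ccc(S(=O)(=O)N2CC[C@@H](Cl)C[C@@H]2c2ccccc2)cc1`, 37000 nM
compound 2, `Cc1ccc(S(=O)(=O)N2CCC(Br)CC2)cc1`, which gives only a limit of the assay, > 100000 nM
compound 3, `Cc1ccc(S(=O)(=O)N2CC[C@@H](Br)C[C@@H]2C2CCCCC2)cc1`, 14000 nM

Compound 3 has the lowest number among the two numbers shown; the nearest is compound 1, which sits higher, beyond the scatter. Going by the values given here, the only step measured in one place is an at least 7.1-fold lower number from compound 2 to compound 3 (0.85 log units; beyond the scatter), and it rests on a limit, (the limit of > 100000 nM in this assay, at which 1 of the 3 values shown sits). Compound 4, `Cc1ccc(S(=O)(=O)N2CC[C@@H](Br)C[C@@H]2c2ccccc2)cc1`, differs from compound 3 by phenyl in place of cyclohexyl on a saturated ring carbon. Among the compounds with values here, no measured step matches this change. Within the data shown here, compound 1 and compound 3 differ in two places, the phenyl or cyclohexyl group and the chloro or bromo group, so their values show only that the phenyl-bearing compound 1 has the higher number. On that basis compound 4 is expected to move in the same direction, with an estimated step of a 2.1-fold higher number from compound 3 to compound 4 (0.33 log units; beyond the scatter) in this assay. Compound 4 is therefore estimated at 30000 nM, within a range from 12000 nM to 80000 nM.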

Compound 4, concentration for 50% growth inhibition: 36000 nM
Estimate against measurement, compound 4: 1.2-fold (0.08 log units) below, and the stated range covers the measured number.
By their numbers in this assay, from the lowest: compound 3; then compounds 4 and 1 (each within the scatter of the next). At a limit, above all of these: compound 2.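

In this assay, the swap at this position can now be read on its own: a 2.6-fold higher number from compound 3 to compound 4 (0.41 log units; beyond the scatter), with phenyl in place of cyclohexyl on a saturated ring carbon, so the aromatic ring of the same size gives the higher number here. Either large group still gives a lower number than hydrogen, with phenyl showing an at least 2.7-fold lower number from compound 2 to compound 4 (0.44 log units; beyond the scatter), but this step rests on a limit: the limit of > 100000 nM in this assay, at which 1 of the 4 values shown sits.
With phenyl in place, the halogen can also be read alone, and bromo in place of chloro gives a 1.0-fold lower number from compound 1 to compound 4 (0.01 log units; within the scatter).

The compounds shown leave open whether the gap between cyclohexyl and phenyl holds with chloro in place of bromo. They also leave open how an amine, a carboxylic acid or a longer chain at this ring carbon would compare with cyclohexyl.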